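Swapping a Maleimide for an Epoxide: Expected Half-Life

The source may hold more compounds than are shown below. What is called first, only, known or untested is meant among the compounds shown, and "the series" means these compounds.

Compound 2 `O=C1C=CC(=O)N1c1cc(C(F)(F)F)cc(C(F)(F)F)c1` was measured in an ADME assay for pharmacokinetics, read by LC-MS, in phosphate buffer, with a stated time of 72 h, at pH 7.4, tested at 250 uM (on this read-out lower numbers stand for a shorter-lived compound and higher numbers for a longer-lived compound), and gives < 0.017 h, which is a limit of the assay rather than a number. Compound 1 `C=CS(=O)(=O)c1cc(C(F)(F)F)cc(C(F)(F)F)c1` in this assay likewise gives < 0.017 h, also a limit. The step that the two limits leave unreadable from compound 1 to compound 2 cannot be sized because of the limit of < 0.017 h in this assay, at which 2 of the 2 values shown sit. Compound 3 `FC(F)(F)c1cc(C2CO2)cc(C(F)(F)F)c1` carries a group of 3 heavy atoms (2 carbon, 1 oxygen; one three-membered non-aromatic ring with 1 hetero atom) in place of a group of 7 heavy atoms (4 carbon, 1 nitrogen, 2 oxygen; one five-membered non-aromatic ring with 1 hetero atom), on an aromatic carbon. Among the compounds with values here, no measured step reads on this change, so any expectation rests on little. For compound 3 a half-life of about 24 h is nonetheless estimated, with a range from 2 h to 200 h. The step of an at least 1400-fold higher number from compound 2 to compound 3 (3.14 log units; beyond the scatter) is thus the expected size, though it remains uncertain.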

Compound 3, half-life: > 50 h
Compound 3 gave a limit, no number (the forecaster's own chance of this, stated with the estimate: 25%); middle value at least 2.0-fold (0.31 log units) away from the limit.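

Compound 1 and compound 2 sat at the same limit, so they showed nothing about how far the group on this aromatic carbon can move the half-life. With oxiran-2-yl there, this assay shows an at least 2900-fold higher number from compound 2 to compound 3 (3.46 log units; beyond the scatter) and also an at least 2900-fold higher number from compound 1 to compound 3 (3.46 log units; beyond the scatter). Compound 3 gives a limit, not a number: the limit of > 50 h in this assay, at which 1 of the 3 values shown sits.

As far as these compounds go, the step from compound 1 to compound 2 still cannot be read, and the true half-life of compound 3 remains unknown. From the compounds shown here alone, whether an amine or a carboxylic acid on this aromatic carbon would give a readable half-life also stays open.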